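The source may hold more compounds than are shown below. What is called first, only, known or untested is meant among the compounds shown, and "the series" means these compounds.

Compound 2 `CC(C)(C)OC(=O)Nc1ncc(C(Oc2ccc3cc(Br)ccc3c2)c2ccc(Cl)cc2)s1` was tested in an ADME assay on HepG2 2.2.15 cells (Homo sapiens) for cytotoxicity; a higher number here means that more compound is tolerated, a lower number that less compound is tolerated. In this assay compound 2 reaches only a limit, > 50000 nM. Compound 1 `CC(C)(C)OC(=O)Nc1ncc(C(Oc2cccc(C#N)c2)c2ccc(Cl)cc2)s1` also gives only a limit in this assay, > 50000 nM. The step that the two limits leave unreadable from compound 1 to compound 2 therefore cannot be read, since both values sit at the limit of > 50000 nM in this assay, at which 2 of the 2 values shown sit. Compound 3 `COCCNc1ncc(C(Oc2ccc3cc(Br)ccc3c2)c2ccc(Cl)cc2)s1` differs from compound 2 in one place: 2-methoxyethyl in place of tert-butoxycarbonyl on a nitrogen on an aromatic ring. Within the data shown here, no measured step bears on this change, and the two limits offer no size for comparison. The step that the limit leaves unreadable from compound 2 to compound 3 is expected to be none beyond the scatter. Compound 3 is estimated at 60000 nM, between 20000 nM and 200000 nM.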

Compound 3, half-maximal cytotoxic concentration: "not toxic" (no number reported)
Nothing numeric was reported for compound 3, so the estimate cannot be set against anything.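

No new step can be read from compound 2 to compound 3: compound 3 is reported only as "not toxic", without a number, and compound 2 gives only a limit. The compounds shown leave open at what concentration any of them turns toxic in this assay.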